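A few compounds are considered here, and "the series" means these few. Any claim that something is new, unique, unknown or untested is made for them only; others in the source may bear on it.

Compound 1 `Cc1cc(=O)[nH]c2cc(NC(=O)c3ccccc3Cl)ccc12` and compound 2 `Cc1ccc(C(=O)Nc2ccc3c(C)cc(=O)[nH]c3c2)cc1` share one core and differ only in the group on the carbonyl carbon. In a physicochemical assay for lipophilicity (on this read-out lower numbers stand for lower lipophilicity and higher numbers for higher lipophilicity), compound 1 gives 1.55, and compound 2 gives 1.67. Compound 2 stands at one end of the two numbers shown, with compound 1 as its only neighbour, and the step of a number 0.12 log units higher from compound 1 to compound 2 (within the scatter) stays within the scatter. Compound 3 `Cc1ccccc1C(=O)Nc1ccc2c(C)cc(=O)[nH]c2c1` carries 2-methylphenyl in place of 4-methylphenyl on a carbonyl carbon. For the measured compounds named here, only that one measured step bears on this change, and it was small, so no step beyond the scatter is expected in this assay. The expected step is a number 0.07 log units lower from compound 2 to compound 3 (within the scatter). For compound 3 the estimated value is 1.6, with a range from 1.3 to 1.9.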

Compound 3, partition coefficient: 1.71
Beside the measured number, compound 3's estimate is 0.11 log units below it; measured number inside the range.
By their numbers in this assay, from the lowest: compounds 1, 2 and 3 (each within the scatter of the next).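

In this assay, 2-methylphenyl in place of 4-methylphenyl on the carbonyl carbon gives a number 0.04 log units higher from compound 2 to compound 3 (within the scatter), so this read-out does not tell the two methylphenyl groups apart. Methyl in place of chloro on an aromatic carbon gives a number 0.16 log units higher from compound 1 to compound 3 (within the scatter), so all three compounds lie within the scatter of one another. Nothing available gives a reason for these numbers. The groups shown on the phenyl ring are only methyl and chloro. On these data alone, whether an amine or a carboxylic acid there would give a step beyond the scatter in this assay stays open.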